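A few compounds are considered here, and "the series" means these few. Any claim that something is new, unique, unknown or untested is made for them only; others in the source may bear on it.

Working notes on the series. The three measured compounds share one core and differ only in the group on a saturated chain carbon bound to an aromatic carbon. In an ADME assay on HEK-293T cells (Homo sapiens) for inhibition, read by CCK-8 assay, with a stated time of 48 h, tested at 20 uM (on this read-out higher numbers stand for more inhibition of growth at the one concentration tested and lower numbers for less inhibition of growth), compound 1 `Cc1ccc(S(=O)(=O)Oc2ccccc2/C=C(\C#N)C(=O)Nc2nnc(Cc3cccc4ccccc34)s2)cc1` gives 23%, compound 2 `Cc1ccc(S(=O)(=O)Oc2ccccc2/C=C(\C#N)C(=O)Nc2nnc(Cc3ccccc3)s2)cc1` gives 15%, and compound 3 `Cc1ccc(S(=O)(=O)Oc2ccccc2/C=C(\C#N)C(=O)Nc2nnc(Cc3cccc(F)c3)s2)cc1` gives 9%. Compound 3 stands lowest of the three numbers, with compound 2 nearest (within the scatter) and compound 1 furthest (beyond the scatter). The recorded steps are a number 8 percentage points lower from compound 1 to compound 2 (within the scatter), a number 14 percentage points lower from compound 1 to compound 3 (beyond the scatter) and a number 6 percentage points lower from compound 2 to compound 3 (within the scatter).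

Compound 4 `Cc1ccc(Cc2nnc(NC(=O)/C(C#N)=C/c3ccccc3OS(=O)(=O)c3ccc(C)cc3)s2)cc1` is not yet measured. It differs from compound 3 in this way: 4-methylphenyl in place of 3-fluorophenyl on a saturated chain carbon bound to an aromatic carbon. Among the compounds with values here, two steps bear on it. The step of a number 6 percentage points lower from compound 2 to compound 3 (within the scatter) shows that fluoro against hydrogen on this ring moves the number only within the scatter, and the step of a number 8 percentage points lower from compound 1 to compound 2 (within the scatter) shows that exchanging the whole ring for phenyl also stays within the scatter; only the naphthalen-1-yl of compound 1 lies beyond it. In this assay no step beyond the scatter is therefore expected, at most a small rise back toward the number of compound 2. Compound 4 is expected to give 14%, with a range from 4% to 26%. The expected step is a number 5 percentage points higher from compound 3 to compound 4 (within the scatter).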

Compound 4, percent growth inhibition at one concentration: 22%
Estimate against measurement, compound 4: 8 percentage points below, within the range that was stated.
By their numbers in this assay, from the lowest: compounds 3, 2, 4 and 1 (each within the scatter of the next, the first and the last beyond it).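

In this assay, within the data shown here, the exchange of 3-fluorophenyl for 4-methylphenyl gives a number 13 percentage points higher from compound 3 to compound 4 (beyond the scatter) and is the first step beyond the scatter between two single rings at this position, so a second fused ring is not required for a step of this size. The other two steps, a number 7 percentage points higher from compound 2 to compound 4 (within the scatter) and a number 1 percentage points lower from compound 1 to compound 4 (within the scatter), stay inside the scatter, so 4-methylphenyl cannot be told apart here from either phenyl or naphthalen-1-yl. No measurement at hand gives a reason for the gap between the 3-fluorophenyl and 4-methylphenyl compounds.

Going by these compounds, compound 3 and compound 4 differ both in the group on the ring and in where it sits, so the share of each in the step stays open. Also open, on these data alone, is how an amine or a carboxylic acid on this ring, or a longer chain in place of the single saturated chain carbon, would read in this assay on the same core.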